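Methyl to methoxy on the benzamide ring of compound 3

A few compounds are considered here, and "the series" means these few. Any claim that something is new, unique, unknown or untested is made for them only; others in the source may bear on it.

Measured compounds:
compound 1 `O=C(NCc1ccc(CNS(=O)(=O)c2ccccc2)cc1)c1cccc(F)c1` — in an assay on MDA-MB-231 cells for binding affinity to C-X-C chemokine receptor type 4 (Homo sapiens), read by immunofluorescence and microscopy, with stated times of 10 min and 30 min (on this read-out lower numbers stand for an effect already at smaller amounts and higher numbers for an effect only at larger amounts of compound), compound 1 gives 100 nM
compound 2 `O=C(NCc1ccc(CNS(=O)(=O)c2ccccc2)cc1)c1ccc(F)cc1` — compound 2 gives 100 nM
compound 3 `Cc1cccc(C(=O)NCc2ccc(CNS(=O)(=O)c3ccccc3)cc2)c1` — compound 3 gives 1000 nM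

Compound 3 carries the highest number of the three, and its steps to both others are beyond the scatter: a 10-fold higher number from compound 1 to compound 3 (1.00 log units; beyond the scatter) and a 10-fold higher number from compound 2 to compound 3 (1.00 log units; beyond the scatter). Between compound 1 and compound 2 there is no change at the digits printed from compound 1 to compound 2 (within the scatter), so moving the fluoro around the ring made no difference, whereas exchanging fluoro for methyl did.

Compound 4 `COc1cccc(C(=O)NCc2ccc(CNS(=O)(=O)c3ccccc3)cc2)c1` is the next step: methoxy in place of methyl on an aromatic carbon. Within the data shown here, no measured pair here exchanges methyl for methoxy, so the only bearing steps are the two that led to compound 3, and they speak of fluoro against methyl, not of methoxy. The direction of the new step is therefore open; a return toward the numbers of compound 1 and compound 2 is possible, as is no change at all. For compound 4 the expectation is no change at the digits printed from compound 3 to compound 4 (within the scatter), that is, a number near that of compound 3. Compound 4 is estimated at 1000 nM, with a range from 300 nM to 3000 nM.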

Compound 4, effective concentration (reported as EC, without a stated level of effect): > 1000 nM
Compound 4 was reported as a limit; the forecaster's own chance of this, stated with the estimate: 10%; the middle value sits exactly at the limit.
By their numbers in this assay, from the lowest: compounds 1 and 2 (each within the scatter of the next); then compound 3.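

In this assay compound 4 gives > 1000 nM, which is a limit and not a number, and it shows no return toward the fluoro compounds: the limit of > 1000 nM in this assay, at which 1 of the 4 values shown sits.

On this aromatic carbon, methoxy brings one hydrogen-bond acceptor that methyl lacks, yet the reading is a number no lower from compound 3 to compound 4 (the limit leaves the size open). Among these compounds, the gap to the fluoro compounds, so far seen only with methyl, now holds for a second group: an at least 10-fold higher number from compound 1 to compound 4 (1.00 log units; beyond the scatter), and likewise an at least 10-fold higher number from compound 2 to compound 4 (1.00 log units; beyond the scatter).

Going by these compounds, how large the step from methyl to methoxy really is stays open. Also open, on these data alone, is what an amine, a hydroxyl or a chloro on this aromatic carbon would give, and whether any group here reaches a lower number than the fluoro compounds.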